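Fluoro for Chloro: What to Expect of Compound 4

This account rests on a few compounds, and the source may have more. Where it says the series, first, only, none or still open, it means among the compounds named here.

Of the compounds shown here, three have been measured so far.
Compound 1, `Cc1cc(Nc2cc(-c3ccccc3)[nH]n2)n2nc(SCc3ccc(F)cc3)nc2n1`, gives 8110 nM in a functional assay on PC-9 cells (Homo sapiens) for inhibition, read by MTT assay, with a stated time of 72 h; a lower number here means a stronger inhibitor, a higher number a weaker inhibitor.
Compound 2, `Cc1cc(Nc2cc(-c3ccccc3)[nH]n2)n2nc(SCc3ccc(Cl)cc3)nc2n1`, gives 6710 nM in this assay.
Compound 3, `Cc1cc(Nc2cc(-c3ccc(Cl)cc3)[nH]n2)n2nc(SCc3ccc(Br)cc3)nc2n1`, gives 4920 nM in this assay.

All three numbers lie within the scatter of one another, so none of them can be set apart as stronger or weaker. The difference between the core of compound 2 and the core of compound 3 is not broken down here; what their two values show is simply that they sit close together.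

Compound 4, `Cc1cc(Nc2cc(-c3ccc(F)cc3)[nH]n2)n2nc(SCc3ccc(Br)cc3)nc2n1`, has not yet been measured in this assay. It differs from compound 3 in one place: fluoro in place of chloro on an aromatic carbon. The same change occurs once more among the compounds shown, from compound 2 to compound 1: fluoro in place of chloro on an aromatic carbon. That earlier step was a 1.2-fold higher number from compound 2 to compound 1 (0.08 log units; within the scatter), a shift that stays within the scatter, and it is the only ground the data give for a forecast.

Resting on that one comparison, the step from compound 3 to compound 4 is expected to be a 1.2-fold higher number from compound 3 to compound 4 (0.08 log units; within the scatter). Compound 4 is therefore expected to give about 5900 nM in this assay. Its likely range is estimated to run from 2500 nM to 13000 nM, the width reflecting that a single prior step is a thin basis.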

Compound 4, half-maximal inhibitory concentration: 6210 nM
The estimate for compound 4 lay 1.1-fold (0.02 log units) below the measured number; the measured number falls inside the stated range.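

The new step in this assay, for fluoro in place of chloro on an aromatic carbon, is a 1.3-fold higher number from compound 3 to compound 4 (0.10 log units; within the scatter). Set beside the earlier case of the same change, the two steps do not differ: the same change on two cores in this assay, a 1.2-fold higher number (0.08 log units; within the scatter) from compound 2 to compound 1 and a 1.3-fold higher number (0.10 log units; within the scatter) from compound 3 to compound 4, 1.0-fold (0.02 log units) apart, within the scatter of two such steps

So far as these two pairs go, the change carried over from one core to the other without a discernible difference, but each step lies within the scatter, so this does not show that the change moves the number at all, and two pairs do not make a rule for the series.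

The compounds shown carry only a halogen or a bare hydrogen at the outer end of their aromatic rings and keep the same methyl group on the shared core, which leaves open what an amine, a methoxy group or a carboxylic acid at those places, or a longer chain in place of the methyl, would do in this assay. On these data alone, all four compounds also sit within a narrow band of values, so it remains open whether any change to this series can shift the number beyond the scatter.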